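The source may report more compounds than this note shows. Statements on the series, on what has been measured and on what is new or still open speak of the compounds shown alone.

Measured in a functional assay on HCT-116 cells (Homo sapiens) for antiproliferative activity, read by MTT assay, with a stated time of 48 h; a higher number here means a weaker inhibitor, a lower number a stronger inhibitor:
- compound 1 `CCNC(=O)Nc1nc(-c2ccc(OCC)cc2)c(-c2cc(OC)c(OC)c(OC)c2)s1` gives 22.1 nM.
- compound 2 `CCOc1ccc(-c2nc(NS(=O)(=O)c3ccc(C)c(C)c3)sc2-c2cc(OC)c(OC)c(OC)c2)cc1` gives > 5000 nM, a limit.
- compound 3 `CCCN(CCC)c1nc(-c2ccc(OCC)cc2)c(-c2cc(OC)c(OC)c(OC)c2)s1` gives > 5000 nM, a limit.

Compound 3 stands at the limit of > 5000 nM in this assay, at which 2 of the 3 values shown sit, so no number is known for it.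

Compound 4 `C=CCN(CC=C)c1nc(-c2ccc(OCC)cc2)c(-c2cc(OC)c(OC)c(OC)c2)s1` carries diallylamino in place of dipropylamino on an aromatic carbon. For the measured compounds named here, no measured step exchanges one such amino group for another. The nearest evidence is large: an at least 220-fold higher number from compound 1 to compound 3 (2.35 log units; beyond the scatter). Also large is an at least 220-fold higher number from compound 1 to compound 2 (2.35 log units; beyond the scatter). The remaining comparison gives little: a step that the two limits leave unreadable from compound 2 to compound 3.

Compound 4, like compound 3, lacks the (ethylcarbamoyl)amino group of compound 1, so it is expected to stay weak in this assay. The expected change, none beyond the scatter, is a number no higher from compound 3 to compound 4 (the limit leaves the size open). The estimate for compound 4 is 5000 nM, with an expected range of 1500 nM to 15000 nM.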

Compound 4, half-maximal inhibitory concentration: > 5000 nM
Compound 4: a limit, no number; the forecaster's own chance of this, stated with the estimate: 75%; the middle value lies on the limit itself.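

In this assay compound 4 gives > 5000 nM, which is a limit and not a number. Diallylamino in place of (ethylcarbamoyl)amino on this aromatic carbon brings an at least 220-fold higher number from compound 1 to compound 4 (2.35 log units; beyond the scatter), and its double bonds give no readable gain over dipropylamino. The steps from compound 3 to compound 4 and from compound 2 to compound 4 cannot be read, and most of the series now sits at one limit: the limit of > 5000 nM in this assay, at which 3 of the 4 values shown sit.

On these data alone, whether a free amino group or an acetylamino group on this carbon gives a readable value stays open. As far as these compounds go, how far compound 2, compound 3 and compound 4 lie beyond the limit also stays open.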